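This account rests on a few compounds, and the source may have more. Where it says the series, first, only, none or still open, it means among the compounds named here.

Compound 1 `C(#Cc1nc2c(s1)CN(C1CCCCC1)CC2)c1ccccc1`: > 10000 nM, a limit of the assay.
Compound 2 `CCC(=O)N1CCc2nc(C#Cc3ccccc3)sc2C1`: > 10000 nM, a limit of the assay.
Compound 3 `CC1CC(C(=O)N2CCc3nc(C#Cc4ccccc4)sc3C2)C1`: 81 nM.

In an assay on HEK293 cells for positive allosteric modulation of metabotropic glutamate receptor 5 (Homo sapiens), read by FLIPR, with a stated time of 1 h (on this read-out higher numbers stand for an effect only at larger amounts of compound and lower numbers for an effect already at smaller amounts), compound 3 gives 81 nM, the only true number among these three; the other two values sit at the limit of > 10000 nM in this assay, at which 2 of the 3 values shown sit. Compound 4 `O=C(C1CCCCC1)N1CCc2nc(C#Cc3ccccc3)sc2C1` differs from compound 3 by cyclohexyl in place of 3-methylcyclobutyl on a carbonyl carbon. Within the data shown here, two measured steps bear on this. The step of an at least 120-fold lower number from compound 2 to compound 3 (2.09 log units; beyond the scatter) shows that a ring on the carbonyl carbon, in place of a short chain, brought a large gain. The step of an at least 120-fold lower number from compound 1 to compound 3 (2.09 log units; beyond the scatter) shows a comparable gain when the amide replaced a plain cyclohexyl on the ring nitrogen. Neither step compares two rings of different size on the carbonyl carbon, so only a modest change is expected. The expected step is a 1.9-fold higher number from compound 3 to compound 4 (0.27 log units; within the scatter). Compound 4 is estimated at 150 nM, within 30 nM to 1000 nM.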

Compound 4, half-maximal effective concentration: 167 nM
Beside the measured number, compound 4's estimate is 1.1-fold (0.05 log units) below it; measured number inside the range.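

Among these compounds, with cyclohexyl in place of 3-methylcyclobutyl on the carbonyl carbon, two rings of different size can be compared directly for the first time, and the result is a 2.1-fold higher number from compound 3 to compound 4 (0.31 log units; beyond the scatter), a modest loss. The large gain over a short chain also holds for cyclohexyl, with an at least 59-fold lower number from compound 2 to compound 4 (1.77 log units; beyond the scatter), and cyclohexylcarbonyl in place of cyclohexyl on an amine nitrogen in a ring gives an at least 59-fold lower number from compound 1 to compound 4 (1.77 log units; beyond the scatter). Both large steps start from a limit, so their true size stays unknown: the limit of > 10000 nM in this assay, at which 2 of the 4 values shown sit.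

Still open, on these data alone, is how a ring containing nitrogen or oxygen, such as piperidine or tetrahydropyran, or an aromatic phenyl ring, would fare on this carbonyl carbon.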